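The source may hold more compounds than are shown below. What is called first, only, known or untested is meant among the compounds shown, and "the series" means these compounds.

In a functional assay on K562 cells (Homo sapiens) for antiproliferative activity, read by MTT assay, with a stated time of 48 h (a higher number here means a weaker inhibitor, a lower number a stronger inhibitor), three compounds have been measured so far, and none gives a number. Compound 1 `COc1cc(CNC(=O)CCCCCCC(C)C)ccc1OCCCCOc1ccc(C(N)=S)cc1` gives > 50000 nM, which is a limit of the assay. Compound 2 `COc1cc(CNC(=O)CCCC/C=C/C(C)C)ccc1OCCCCOc1ccc(C(N)=S)cc1` gives > 50000 nM, which is also a limit. Compound 3 `COc1cc(CNC(=O)CCCC/C=C/C(C)C)ccc1OCCCCOc1ccc(-c2cc(=S)ss2)cc1` gives > 50000 nM, and this too is a limit, so it has no measured potency to start from. Compound 4 `COc1cc(CNC(=O)CCCCCCC(C)C)ccc1OCCCCOc1ccc(-c2cc(=S)ss2)cc1` differs from compound 3 in one place: isopentyl in place of 3-methylbut-1-en-1-yl on a saturated chain carbon, four bonds along the chain from a carbonyl carbon. The closest evidence is a step that the two limits leave unreadable from compound 1 to compound 2, which is the same exchange run the other way on the other end group. The second measured change, a step that the two limits leave unreadable from compound 2 to compound 3, concerns that end group and has no readable size either. Neither supplies a size or direction to carry over. Compound 4 is therefore expected to remain near the limit because of the limit of > 50000 nM in this assay, at which 3 of the 3 values shown sit. The expected change is a number no higher from compound 3 to compound 4 (the limit leaves the size open), with no direction predicted. For compound 4, the estimated value is 50000 nM, with an expected range from 20000 nM to 100000 nM.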

Compound 4, half-maximal inhibitory concentration: > 50000 nM
Compound 4 was reported as a limit; the forecaster's own chance of this, stated with the estimate: 80%; the middle value sits exactly at the limit.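

Compound 4 is reported only as a limit in this assay, as are compound 3 and compound 1, so the steps to compound 4 from those two compounds cannot be read. The compounds shown leave open whether either exchange alters potency, and in which direction: the limit of > 50000 nM in this assay, at which 4 of the 4 values shown sit.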